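The source may report more compounds than this note shows. Statements on the series, on what has been measured and on what is new or still open speak of the compounds shown alone.

Compound 1 `CCCSc1nc(N/N=C/c2ccccc2F)c2nnn(Cc3ccccc3)c2n1`: in a functional assay on MCF7 cells (Homo sapiens) for antiproliferative activity, read by MTT assay, with a stated time of 72 h (a higher number here means a weaker inhibitor, a lower number a stronger inhibitor), compound 1 gives > 64000 nM, which is a limit of the assay rather than a number.
Compound 2 `CCCSc1nc(N/N=C/c2ccccc2Cl)c2nnn(Cc3ccccc3)c2n1`: in this assay compound 2 gives 13800 nM.
Compound 3 `CCCSc1nc(N/N=C/c2cc(OC)c(OC)c(OC)c2)c2nnn(Cc3ccccc3)c2n1`: in this assay compound 3 gives > 64000 nM, again a limit of the assay rather than a number.

Compound 3 therefore stands at the limit of > 64000 nM in this assay, at which 2 of the 3 values shown sit, so no number for it is known, only the limit itself. Within the data shown here, the single measured step, an at least 4.6-fold lower number from compound 1 to compound 2 (0.66 log units; beyond the scatter), concerns a different part of the shared core and says nothing about the change followed here. Compound 4 `C#CCSc1nc(N/N=C/c2cc(OC)c(OC)c(OC)c2)c2nnn(Cc3ccccc3)c2n1` differs from compound 3 by ethynyl in place of ethyl on a saturated chain carbon bound to a sulfur. Among the measured compounds shown here, with no measured step touching this position, the expectation for compound 4 has to rest on where compound 3 stands, which is at the limit of the assay. The step expected in this assay is an at least 1.0-fold lower number from compound 3 to compound 4 (0.02 log units; that floor lies within the scatter), meaning compound 4 is expected to stay weak. Compound 4 is estimated at 60000 nM, with a range from 15000 nM to 250000 nM, and it may well again return only a limit.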

Compound 4, half-maximal inhibitory concentration: 17000 nM
Compound 4: middle estimate off by 3.5-fold (0.55 log units), on the high side, within the range that was stated.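

Among these compounds, the earlier step touched a different part of the shared core, so this is the first reading on the chain at the sulfur in this assay: ethynyl in place of ethyl there gives an at least 3.7-fold lower number from compound 3 to compound 4 (0.57 log units; beyond the scatter). Ethyl and ethynyl hold the same number of heavy atoms, and the one counted difference between them is the triple bond. Compound 3 gives only a limit, so the true size of this step could be larger: the limit of > 64000 nM in this assay, at which 2 of the 4 values shown sit.

Among the compounds shown here, the propargylsulfanyl chain appears here with only one aromatic group on the hydrazone side, so it remains open whether the lower number would carry over to the fluoro or chloro compounds. Also open, going by these compounds, is how a butyl chain or an amine would fare at this position.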